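Moving on from the trifluoromethylphenyl group of compound 2

The source may report more compounds than this note shows. Statements on the series, on what has been measured and on what is new or still open speak of the compounds shown alone.

In a functional assay on SGC-7901 cells (Homo sapiens) for antiproliferative activity, read by MTT assay, with a stated time of 72 h (on this read-out lower numbers stand for stronger inhibition and higher numbers for weaker inhibition), compound 1 (`CCOc1ccc(-c2ccc3ncn(-c4cc(OC)c(OC)c(OC)c4)c3c2)cc1`) gives 2970 nM as its reading, while compound 2 (`COc1cc(-n2cnc3ccc(-c4ccc(C(F)(F)F)cc4)cc32)cc(OC)c1OC`) gives 890 nM and so holds the lower of the two numbers. Compound 3 (`COc1cc(-n2cnc3ccc(-c4cccc(C)c4)cc32)cc(OC)c1OC`) departs from compound 2 by one change, 3-methylphenyl in place of 4-(trifluoromethyl)phenyl on an aromatic carbon with 3-methylphenyl in place of 4-(trifluoromethyl)phenyl on an aromatic carbon. Among the measured compounds shown here, the only measured step is a 3.3-fold lower number from compound 1 to compound 2 (0.52 log units; beyond the scatter) and it is modest, though beyond the scatter. For the measured compounds named here, it bears on the new change only indirectly, since it exchanged ethoxy for trifluoromethyl and no measured compound carries 3-methylphenyl. With that single step as a guide, a change of similar modest size toward a higher number is expected. The estimate is a 1.7-fold higher number from compound 2 to compound 3 (0.23 log units; within the scatter) and it stays uncertain. In this assay the estimated value for compound 3 is 1500 nM with a range from 500 nM to 4500 nM expected.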

Compound 3, half-maximal inhibitory concentration: 1240 nM
Compound 3: the middle estimate sits 1.2-fold (0.08 log units) above what was measured; measured number inside the range.
By their numbers in this assay, from the lowest: compounds 2 and 3 (each within the scatter of the next); then compound 1.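

In this assay, 3-methylphenyl in place of 4-(trifluoromethyl)phenyl gives a 1.4-fold higher number from compound 2 to compound 3 (0.14 log units; within the scatter) and so cannot be told apart from it, which shows that a group of carbon only can serve here as well as the fluorine-bearing one. Set against 4-ethoxyphenyl, the same group gives a 2.4-fold lower number from compound 1 to compound 3 (0.38 log units; beyond the scatter) and so makes compound 1 the one that stands apart, as both replacements of 4-ethoxyphenyl shown lead to a lower number. Nothing available explains these readings.

The change alters both the substituent and its place on the phenyl ring, so the compounds shown cannot separate those two effects, as 4-methylphenyl could. They also leave open how this position would respond to an amine or a carboxylic acid on that ring.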